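The source may hold more compounds than are shown below. What is called first, only, known or untested is meant among the compounds shown, and "the series" means these compounds.

- Compound 1 `COc1cc(-n2cnc3ccc(-c4ccc([N+](=O)[O-])cc4)cc32)cc(OC)c1OC`: 740 nM
- Compound 2 `COc1cc(-n2cnc3ccc(-c4ccc(Cl)cc4Cl)cc32)cc(OC)c1OC`: 5420 nM

In a functional assay on MCF7 cells (Homo sapiens) for antiproliferative activity, read by MTT assay, with a stated time of 72 h (on this read-out lower numbers stand for stronger inhibition and higher numbers for weaker inhibition), compound 2 gives the higher of the two numbers, 5420 nM. Compound 3 `COc1cccc(-c2ccc3ncn(-c4cc(OC)c(OC)c(OC)c4)c3c2)c1` has 3-methoxyphenyl in place of 2,4-dichlorophenyl on an aromatic carbon. Within the data shown here, only one measured step bears on this, a modest change of group on that carbon: a 7.3-fold higher number from compound 1 to compound 2 (0.86 log units; beyond the scatter). A step of similar or smaller size towards a lower number is therefore expected in this assay, though this single step cannot fix its size. The expected change is a 2.7-fold lower number from compound 2 to compound 3 (0.43 log units; beyond the scatter). For compound 3 the estimate is 2000 nM, with an expected range of 600 nM to 6500 nM.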

Compound 3, half-maximal inhibitory concentration: 1610 nM
Compound 3: the middle estimate sits 1.2-fold (0.09 log units) above what was measured; measured number inside the range.
By their numbers in this assay, from the lowest: compound 1; then compound 3; then compound 2.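

Read in this assay, the change to 3-methoxyphenyl gives a 3.4-fold lower number from compound 2 to compound 3 (0.53 log units; beyond the scatter) and, set against 4-nitrophenyl, a 2.2-fold higher number from compound 1 to compound 3 (0.34 log units; beyond the scatter) in this same comparison of groups on that aromatic carbon. The number for compound 3 therefore falls inside the span set by compound 1 and compound 2, so this position gives graded values across three substituted phenyl groups rather than a single split. Nothing measured here explains this order. The compounds shown leave open how an amine or a carboxylic acid on this phenyl ring would read, and whether a saturated ring such as morpholine could replace the phenyl ring at this carbon.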